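A few compounds are considered here, and "the series" means these few. Any claim that something is new, unique, unknown or untested is made for them only; others in the source may bear on it.

Measured compounds:
- compound 1, `COc1cc(NC(C)CCCNC(=O)NNC(=O)Nc2ccc(Cl)cc2)c2ncccc2c1`: 108000 nM
- compound 2, `COc1cc(NC(C)CCCNC(=O)NNC(=O)Nc2cccc(C(F)(F)F)c2)c2ncccc2c1`: 6900 nM

In a functional assay on CCRF-CEM cells (Homo sapiens) for inhibition, read by MTT assay, with a stated time of 72 h (a lower number here means a stronger inhibitor, a higher number a weaker inhibitor), compound 1 gives 108000 nM, the highest of the two numbers on hand. Its nearest neighbour, compound 2, gives 6900 nM, and the step between them is a 16-fold lower number from compound 1 to compound 2 (1.19 log units; beyond the scatter), a large move that followed the exchange of 4-chlorophenyl for 3-(trifluoromethyl)phenyl on the terminal urea nitrogen.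

Compound 3, `COc1cc(NC(C)CCCNC(=O)NNC(=O)Nc2ccc(O)cc2)c2ncccc2c1`, keeps the shared core and the 4-substituted pattern of compound 1 but carries hydroxy in place of chloro on an aromatic carbon. Within the data shown here, no measured step tracks this particular exchange: the only step known, from compound 1 to compound 2, changes both the substituent and its position at once, so it speaks only to how sensitive the terminal aryl group is, not to what a hydroxy group does there. With that single data point, the expected step of a 1.1-fold higher number from compound 1 to compound 3 (0.05 log units; within the scatter) is taken as none beyond the scatter, with wide uncertainty in either direction. Compound 3 is therefore estimated at 120000 nM, within a range from 35000 nM to 400000 nM.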

Compound 3, half-maximal inhibitory concentration: 111000 nM
Estimate against measurement, compound 3: 1.1-fold (0.03 log units) above; low and high end bracket the measured number.
By their numbers in this assay, from the lowest: compound 2; then compounds 1 and 3 (each within the scatter of the next).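

In this assay, hydroxy in place of chloro on the aromatic carbon para to a large group gives a 1.0-fold higher number from compound 1 to compound 3 (0.01 log units; within the scatter) even though the entering group brings a hydrogen-bond donor and a hydrogen-bond acceptor that chloro lacks. Among the compounds shown, the 4-chlorophenyl and 4-hydroxyphenyl groups therefore read alike, whereas the step to the 3-(trifluoromethyl)phenyl group remains large, with a 16-fold higher number from compound 2 to compound 3 (1.21 log units; beyond the scatter) in the other direction. Among these compounds, the earlier pair showed only that the terminal aryl group can matter, while this result shows that not every change there moves the number. No measurement on hand bears on the reason for this result.

On these data alone, whether the lower number of compound 2 goes with the trifluoromethyl group itself or with its place on the ring stays open, and trifluoromethyl on the aromatic carbon that carries chloro in compound 1 would be needed to separate the two. Also open, as far as these compounds go, is how an amine or a carboxylic acid on that same carbon would read, since two groups there cannot show whether this carbon tolerates change in general.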